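Benzyl Ether on the Phenol Oxygen of Compound 3

This account rests on a few compounds, and the source may have more. Where it says the series, first, only, none or still open, it means among the compounds named here.

Measured so far in a functional assay on HCT-15 cells (Homo sapiens) for antiproliferative activity, read by XTT assay; on this read-out lower numbers stand for stronger inhibition and higher numbers for weaker inhibition:
compound 1 `CC(C)COc1cccc2occ(Cc3coc4ccccc4c3=O)c(=O)c12` gives > 10000 nM, which is a limit of the assay.
compound 2 `O=c1c(Cc2coc3ccccc3c2=O)coc2ccccc12` gives > 10000 nM, which is a limit of the assay.
compound 3 `O=c1c(Cc2coc3cccc(O)c3c2=O)coc2ccccc12` gives > 10000 nM, which is a limit of the assay.

Compound 3 therefore stands at the limit, and the whole evidence is the limit of > 10000 nM in this assay, at which 3 of the 3 values shown sit. Compound 4 `O=c1c(Cc2coc3cccc(OCc4ccccc4)c3c2=O)coc2ccccc12` differs from compound 3 by benzyl in place of hydrogen on an oxygen on an aromatic ring. Among the compounds with values here, the steps that bear on this change, a step that the two limits leave unreadable from compound 1 to compound 3 at the same oxygen and a step that the two limits leave unreadable from compound 2 to compound 3 at the same carbon, together with a step that the two limits leave unreadable from compound 1 to compound 2, are all unreadable between limits, so no direction can be read for the benzyl. The expected step that the limit leaves unreadable from compound 3 to compound 4 is thus none beyond the scatter, most likely a limit again. Compound 4 is estimated at 15000 nM, within 4000 nM to 60000 nM.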

Compound 4, half-maximal inhibitory concentration: > 10000 nM
Compound 4 gave a limit, no number; the forecaster's own chance of this, stated with the estimate: 80%; the middle value does not contradict the limit.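

Within the data shown here, compounds 1, 2, 3 and 4 all sit at a limit, so no step to compound 4 can be read in this assay: the limit of > 10000 nM in this assay, at which 4 of the 4 values shown sit. Going by these compounds, whether this assay gives a number for any group on the shared core stays open.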